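Sulfonyl sulfur substituent swap: compound 2 toward compound 4

The source may hold more compounds than are shown below. What is called first, only, known or untested is meant among the compounds shown, and "the series" means these compounds.

Measured compounds:
compound 1, `CCN(CC)S(=O)(=O)c1ccc(S(=O)(=O)N2CCC[C@@H](C(=O)N3CC4(CCN(C(=O)OC(C)(C)C)C4)C3)C2)cc1`: 900 nM
compound 2, `CCC(CC)S(=O)(=O)c1ccc(S(=O)(=O)N2CCC[C@@H](C(=O)N3CCN(c4nc(C(C)C)no4)CC3)C2)cc1`: 120 nM
compound 3, `CCN(CC)S(=O)(=O)c1ccc(S(=O)(=O)N2CCC[C@@H](c3cc(C)no3)C2)cc1`: 7700 nM

In a functional assay on BXPC-3 cells (Homo sapiens) for inhibition, read by MTT assay, with a stated time of 7 days (a lower number here means a stronger inhibitor, a higher number a weaker inhibitor), compound 2 gives 120 nM, the lowest of the three numbers. Compound 1 gives 900 nM and compound 3 gives 7700 nM; both gaps to compound 2 lie beyond the scatter, so compound 2 is the strongest inhibitor among those measured.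

Compound 4 `CC(C)c1noc(N2CCN(C(=O)[C@@H]3CCCN(S(=O)(=O)c4ccc(S(=O)(=O)NC5CCC5)cc4)C3)CC2)n1` is not yet measured. It differs from compound 2 in one place: cyclobutylamino in place of pentan-3-yl on a sulfonyl sulfur. Among the compounds with values here, no measured pair differs only at this position, so there is no step to lean on. Without such a reference, a step of modest size toward a higher number is expected, not beyond one small step from the scatter. Compound 4 is expected to give about 250 nM, with a range of 80 nM to 800 nM. That estimate corresponds to a step of a 2.1-fold higher number from compound 2 to compound 4 (0.32 log units; beyond the scatter).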

Compound 4, half-maximal inhibitory concentration: 3300 nM
Beside the measured number, compound 4's estimate is 13-fold (1.12 log units) below it; the measured number lies above the stated range.
By their numbers in this assay, from the lowest: compound 2; then compound 1; then compound 4; then compound 3.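

In this assay the sulfonyl sulfur substituent is a sensitive position: cyclobutylamino in place of pentan-3-yl gives a 28-fold higher number from compound 2 to compound 4 (1.44 log units; beyond the scatter) with the rest of the structure unchanged. Within the data shown here, this is the first pair to isolate this position, and the two groups hold the same count of heavy atoms, yet the step is large. Nothing measured here bears on the reason for the step.

The ring and the amine nitrogen change together, so their contributions stay unseparated. Cyclobutyl attached directly to the sulfonyl sulfur, or N-methylcyclobutylamino at the same place, would pull them apart.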